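Estimating a benzyl ester from a compound without a number

A few compounds are considered here, and "the series" means these few. Any claim that something is new, unique, unknown or untested is made for them only; others in the source may bear on it.

Measured so far in an ADME assay on cells (spleen, Mus musculus, strain C57BL/6) for inhibition, read by flow cytometry and propidium iodide staining, with a stated time of 24 h, at 37 degrees C; a higher number here means that more compound is needed for the effect, a lower number that less compound is needed
compound 1 `O=C(Cn1cc(C(=O)O)nn1)NCc1ccccc1` gives "non-toxic" (no number reported)
compound 2 `Nc1cccc(-c2cn(CC(=O)NCc3ccccc3)nn2)c1` gives 800 uM
compound 3 `Cc1ccccc1-c1cn(CC(=O)NCc2ccccc2)nn1` gives 940 uM

In this assay compound 1 gives "non-toxic" (no number reported) as its result. That is a verdict and not a number, so compound 1 offers no starting value to measure a step from.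

Compound 4 `O=C(Cn1cc(C(=O)OCc2ccccc2)nn1)NCc1ccccc1` differs from compound 1 in one place, and the difference counts out as benzyl in place of hydrogen on an oxygen next to a carbonyl group in this comparison. Cut one bond further out, the same change reads as hydroxy to benzyloxy.

Among the compounds with values here, the only measured step is a 1.2-fold higher number from compound 2 to compound 3 (0.07 log units; within the scatter) and it lies within the scatter. It swaps 2-methylphenyl for 3-aminophenyl on an aromatic carbon, which is a different change. Within the data shown here, no measured step starts from compound 1, so no step size or direction can be carried over.

What remains is a general level. Compound 2 gives 800 uM and compound 3 gives 940 uM in this comparison, and both carry an aromatic ring in the part of the molecule where compound 4 gains its benzyl. On that basis alone, and with wide uncertainty, the expected value for compound 4 is 700 uM within an estimated range of 250 uM to 1800 uM in this assay when it is measured.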

Compound 4, concentration for half-maximal effect: 720 uM
Beside the measured number, compound 4's estimate is 1.0-fold (0.01 log units) below it; the range from low to high includes it.
By their numbers in this assay, from the lowest: compounds 4, 2 and 3 (each within the scatter of the next).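

No new step can be read here: in this assay compound 1 gives "non-toxic" (no number reported) as a verdict without a number, so the difference from compound 4 has no size. The compounds shown leave open how far benzyl in place of hydrogen moves the number in this assay on its own. Nothing at hand bears on what lies behind the result for compound 4.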